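The source may report more compounds than this note shows. Statements on the series, on what has been measured and on what is new or still open speak of the compounds shown alone.

Working notes on the series. Compound 3 `CCOC(=O)CN(Cc1cc(F)cc(F)c1)c1ccc2c(c1)N(C)CC(C)(COc1ccc(C(=N)N)cc1)O2` gives 6700 nM in a functional assay on HMEC-1 cells (Homo sapiens) for antiproliferative activity, read by cell counting, with a stated time of 7 days (a lower number here means a stronger inhibitor, a higher number a weaker inhibitor), the lowest of the two numbers shown; compound 1 `CCOC(=O)CN(Cc1cc(F)cc(F)c1)c1ccc2c(c1)OC(C)(COc1ccc(C#N)cc1)CN2C` gives 49000 nM in this assay. Compound 2 `CCOC(=O)C(=O)N(Cc1ccccc1)c1ccc2c(c1)OC(C)(CO)CN2C` reaches only the limit of this assay at > 100000 nM (the limit of > 100000 nM in this assay, at which 1 of the 3 values shown sits). Compound 4 `CCOC(=O)CN(Cc1cc(F)cc(F)c1)c1ccc2c(c1)N(C)CC(C)(COc1ccc(C#N)cc1)O2` is not yet measured in this assay; it keeps the core of compound 3, and compound 4 differs from compound 3 by a group of 2 heavy atoms (1 carbon, 1 nitrogen; no ring) in place of a group of 3 heavy atoms (1 carbon, 2 nitrogen; no ring), on an aromatic carbon. The expected step is a 5.2-fold higher number from compound 3 to compound 4 (0.72 log units; beyond the scatter), in the weaker direction and beyond the scatter, with compound 1, which also carries the cyano group, giving 49000 nM as the nearest point of reference. For compound 4 the expected value in this assay is 35000 nM, within 12000 nM to 100000 nM.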

Compound 4, half-maximal inhibitory concentration: > 100000 nM
Compound 4 gave a limit, no number (the forecaster's own chance of this, stated with the estimate: 20%); middle value at least 2.8-fold (0.45 log units) from the limit.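

Among these compounds, this is the first matched pair: with the core of compound 3 kept, cyano in place of the group of 3 heavy atoms (1 carbon, 2 nitrogen; no ring), on an aromatic carbon para to a large group, gives an at least 14-fold higher number from compound 3 to compound 4 (1.17 log units; beyond the scatter) in this assay. From the compounds shown here alone, the result for compound 4 is a limit of the assay, not a number, so the step's full size is unknown. The read-out is capped for part of the series: the limit of > 100000 nM in this assay, at which 2 of the 4 values shown sit.

Going by these compounds, whether an amine or a carboxylic acid at this aromatic carbon would hold the activity of compound 3 stays open.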